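Methyl removal on the fused core: compound 4

This account rests on a few compounds, and the source may have more. Where it says the series, first, only, none or still open, it means among the compounds named here.

Compound 2 `COc1cccc(-c2cc(O)c3c(C)cc(C)nc3n2)c1` sits lowest of the three measured: in a functional assay on SK-MEL-5 cells (Homo sapiens) (a higher number here means a weaker inhibitor of growth, a lower number a stronger inhibitor of growth), compound 2 gives 288 nM. Compound 3 `Cc1ccnc2nc(-c3ccc(Cl)cc3)cc(O)c12` gives 3470 nM and compound 1 `Oc1cc(-c2ccc(Cl)cc2)nc2ncccc12` gives 28800 nM. The difference between the cores of compound 2 and compound 3 is not broken down here. Compound 3 and compound 1 differ by one change, (hydrogen in place of methyl on an aromatic carbon), and the step was an 8.3-fold higher number from compound 3 to compound 1 (0.92 log units; beyond the scatter). Compound 4 `COc1cccc(-c2cc(O)c3c(C)ccnc3n2)c1` carries the same kind of change against compound 2, (hydrogen in place of methyl on an aromatic carbon), but at a different place: next to the ring nitrogen, meta to a methyl group and para to a fused ring, rather than ortho to a fused ring and opposite the ring nitrogen. Because an 8.3-fold higher number from compound 3 to compound 1 (0.92 log units; beyond the scatter) went one way, the step from compound 2 to compound 4 is expected to be similar, a 5.2-fold higher number from compound 2 to compound 4 (0.72 log units; beyond the scatter), with wider uncertainty. Compound 4 is estimated at 1500 nM, between 400 nM and 6000 nM.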

Compound 4, concentration for 50% growth inhibition: 22.4 nM
For compound 4 the middle estimate is 67-fold (1.83 log units) above the measured one; the measured number lies below the stated range.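

In this assay, hydrogen in place of methyl next to the ring nitrogen gives a 13-fold lower number from compound 2 to compound 4 (1.11 log units; beyond the scatter). Set beside the earlier step, this change does not carry over as a fixed shift from one core to another in this series: the same change on two cores in this assay, an 8.3-fold higher number (0.92 log units; beyond the scatter) from compound 3 to compound 1 and a 13-fold lower number (1.11 log units; beyond the scatter) from compound 2 to compound 4, 110-fold (2.03 log units) apart, beyond the scatter of two such steps. The two steps lie at different places on different cores, so they show that the direction cannot be transferred between these compounds, but not whether the place or the rest of the core decides it.

Still open, as far as these compounds go, is whether an ethyl group or an amine next to the ring nitrogen would keep the low number of compound 4. Also open, from the compounds shown here alone, is how compound 4 responds to replacing its remaining methyl with hydrogen.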